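The source may hold more compounds than are shown below. What is called first, only, known or untested is meant among the compounds shown, and "the series" means these compounds.

Measured compounds:
- Compound 1 `CCCn1cc(-c2cnc(NCc3ccc4sccc4c3)c(C(=O)NCC3COc4ccccc4O3)c2)cn1`: 400 nM
- Compound 2 `CCCn1cc(-c2cnc(NCc3ccc4occc4c3)c(C(=O)NCC3COc4ccccc4O3)c2)cn1`: 720 nM
- Compound 3 `CCCn1cc(-c2cnc(NCc3ccc4ncsc4c3)c(C(=O)NCC3COc4ccccc4O3)c2)cn1`: 900 nM

In an assay on HEK293 cells for agonist activity at growth hormone secretagogue receptor type 1 (Rattus norvegicus), read by a luciferase reporter (on this read-out higher numbers stand for weaker inhibition and lower numbers for stronger inhibition), compound 3 gives the highest of the three numbers. Its nearest neighbour is compound 2, and the step of a 1.3-fold higher number from compound 2 to compound 3 (0.10 log units; within the scatter) is within the scatter, so no order between these two can be read. Its furthest neighbour is compound 1, and the step of a 2.3-fold higher number from compound 1 to compound 3 (0.35 log units; beyond the scatter) is beyond the scatter, though modest.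

Compound 4 `CCCn1cc(-c2cnc(NCc3ccc4c(c3)OCC4)c(C(=O)NCC3COc4ccccc4O3)c2)cn1` differs from compound 3 by a group of 9 heavy atoms (8 carbon, 1 oxygen; one five-membered non-aromatic ring with 1 hetero atom, one six-membered aromatic ring of carbon only) in place of a group of 9 heavy atoms (7 carbon, 1 nitrogen, 1 sulfur; one five-membered aromatic ring with 2 hetero atoms, one six-membered aromatic ring of carbon only), on a saturated chain carbon bound to a nitrogen on an aromatic ring. The three measured steps all exchange one bicyclic group for another at this same place: a 1.8-fold higher number from compound 1 to compound 2 (0.26 log units; within the scatter), a 2.3-fold higher number from compound 1 to compound 3 (0.35 log units; beyond the scatter), a 1.3-fold higher number from compound 2 to compound 3 (0.10 log units; within the scatter). Within the data shown here, all of them are small, and none of them brings in a non-aromatic five-membered ring, so the present change has no direct precedent. Given how little the group at this place has moved the numbers so far, the expected step in this assay is none beyond the scatter, with the estimate set near the middle of the observed spread. Compound 4 is therefore estimated at 700 nM, with a range from 300 nM to 1800 nM. This estimate corresponds to an expected step of a 1.3-fold lower number from compound 3 to compound 4 (0.11 log units; within the scatter).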

Compound 4, half-maximal inhibitory concentration: 140 nM
Compound 4: middle estimate off by 5.0-fold (0.70 log units), on the high side, outside the stated range (below it).
By their numbers in this assay, from the lowest: compound 4; then compounds 1, 2 and 3 (each within the scatter of the next, the first and the last beyond it).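

In this assay the group on a saturated chain carbon bound to a nitrogen on an aromatic ring can move the number well beyond the scatter: the bicyclic group with a five-membered non-aromatic ring gives a 6.4-fold lower number from compound 3 to compound 4 (0.81 log units; beyond the scatter) and a 5.1-fold lower number from compound 2 to compound 4 (0.71 log units; beyond the scatter) and also a 2.9-fold lower number from compound 1 to compound 4 (0.46 log units; beyond the scatter) in the same direction. Among the earlier compounds, only one step at this place lay beyond the scatter, so the fully aromatic bicyclic groups had suggested a flat position, and the non-aromatic ring now stands apart from all three. No measurement shown here bears on why the number falls.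

Whether the ring oxygen is needed stays open, as no indanyl group stands at this place among the compounds shown. Also open, as far as these compounds go, is whether a single ring such as phenyl or cyclohexyl would serve as well.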